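A few compounds are considered here, and "the series" means these few. Any claim that something is new, unique, unknown or untested is made for them only; others in the source may bear on it.

Working notes on the series. Three analogues sharing one core have been tested in a functional assay on MOLT-4 cells (Homo sapiens) for cytotoxicity, read by sulforhodamine B assay, with a stated time of 48 h, tested at 0.01 uM; a higher number here means a weaker effect of the compound at the concentration tested, a lower number a stronger effect. Compound 1 `COc1cc(C)cc(-c2c(-c3ccnc(-c4ccc(C(C)=O)cc4)c3)cnn2CC#N)c1` gives 99% in this assay, compound 2 `COc1cc(C)cc(-c2nn(CC#N)cc2-c2ccc(-c3cccc(C(C)=O)c3)nc2)c1` gives 100%, and compound 3 `Cc1cc(O)cc(-c2nn(CC#N)cc2-c2ccnc(-c3ccc(Oc4ccccc4)cc3)c2)c1` gives 93%. Compound 1 stands second highest of the three numbers; compound 2 lies nearest to it and compound 3 furthest, both gaps within the usual scatter, so the three are indistinguishable at this concentration.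

Compound 4 `COc1cc(C)cc(-c2c(-c3ccnc(-c4ccc(N(C)C)cc4)c3)cnn2CC#N)c1` is not yet measured. It differs from compound 1 by dimethylamino in place of acetyl on an aromatic carbon. Going by the values given here, no pair differing in one place has been measured, so the size of this step is unknown; with all three measured values near the top of the scale, no step beyond the scatter in this assay is expected. For compound 4 a value of 98% is estimated, within 88% to 105%, meaning an expected step of a number 1 percentage points lower from compound 1 to compound 4 (within the scatter).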

Compound 4, a percentage reported as activity, at one concentration (the size of the read-out at that concentration, not a potency): 81%
Compound 4: the middle estimate sits 17 percentage points above what was measured; measured number outside the range, below it.
By their numbers in this assay, from the lowest: compound 4; then compounds 3, 1 and 2 (each within the scatter of the next).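

Going by these compounds alone, the exchange of acetyl for dimethylamino on this aromatic carbon gives a number 18 percentage points lower from compound 1 to compound 4 (beyond the scatter) in this assay, the first step beyond the scatter. The group at this position can therefore change the read-out at this concentration, and the change runs towards a stronger effect, which the three earlier compounds did not show. Nothing available explains this step.

As far as these compounds go, whether the dimethylamino group itself matters or other groups at this carbon would do the same stays open. A primary amine, a methoxy group or a carboxylic acid there would help to decide this.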